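A Carboxylic Acid Enters the Side Ring

This account rests on a few compounds, and the source may have more. Where it says the series, first, only, none or still open, it means among the compounds named here.

compound 1 `O=C1c2ccc(OCc3cccc(-c4ccc(Cl)cc4F)c3)cc2CN1C1CCCC1` — > 5000 nM
compound 2 `O=C(O)c1cc(-c2cccc(COc3ccc4c(=O)n(C5CCC5)sc4c3)c2)ccc1Cl` — 580 nM

Of the compounds shown here, two have been measured in an assay on HEK293 cells for positive allosteric modulation of metabotropic glutamate receptor 2 (Rattus norvegicus), read by thallium flux; on this read-out higher numbers stand for an effect only at larger amounts of compound and lower numbers for an effect already at smaller amounts. For compound 1 the result is only a limit of that assay, > 5000 nM, so where compound 1 truly stands cannot be read from the numbers (the limit of > 5000 nM in this assay, at which 1 of the 2 values shown sits). Compound 2, built on a different core, gives 580 nM in this assay. Compound 3, `O=C(O)c1ccc(Cl)c(-c2cccc(COc3ccc4c(c3)CN(C3CCCC3)C4=O)c2)c1`, keeps the core of compound 1 and carries 5-carboxy-2-chlorophenyl in place of 4-chloro-2-fluorophenyl on an aromatic carbon, that is a 5-carboxy-2-chlorophenyl in place of 4-chloro-2-fluorophenyl on an aromatic carbon. Among the measured compounds shown here, no pair of measured compounds differs in one place, so no measured step fixes the size of this change. For the measured compounds named here, compound 2 shows only that a compound bearing the same 5-carboxy-2-chlorophenyl on another core acts at smaller amounts. Compound 3 is expected to move by an at least 3.3-fold lower number from compound 1 to compound 3 (0.52 log units; beyond the scatter) toward an effect at smaller amounts. Compound 3 is estimated at 1500 nM, with a range from 400 nM to 5000 nM.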

Compound 3, half-maximal effective concentration: 90 nM
For compound 3 the middle estimate is 17-fold (1.22 log units) above the measured one; the measured number lies below the stated range.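

The measured step now gives this change a size on a single core in this assay: replacing 4-chloro-2-fluorophenyl with 5-carboxy-2-chlorophenyl produces an at least 55-fold lower number from compound 1 to compound 3 (1.74 log units; beyond the scatter). Compound 1 stands at a limit of the assay, so this step is a minimum and its full size cannot be read: the limit of > 5000 nM in this assay, at which 1 of the 3 values shown sits. At this aromatic carbon, meta to a large group, the swap of one side ring for the other is thus tied to a large shift toward an effect at smaller amounts, with the rest of the molecule unchanged.

The whole side ring differs between the two compounds, so the share of the carboxy group cannot be separated from that of the other differences between the rings. From the compounds shown here alone, whether a methyl ester or a primary amide in its place would act in the same way also remains open.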